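The source may hold more compounds than are shown below. What is called first, only, known or untested is meant among the compounds shown, and "the series" means these compounds.

For the measured compounds named here, compound 2 `O=C(CCc1cccc2c1B(O)OC2)Nc1ccc(Cl)cc1` is the only compound with a measured number: in a functional assay on SK-OV-3 cells (Homo sapiens) for antiproliferative activity, read by MTT assay, with a stated time of 72 h (on this read-out lower numbers stand for stronger inhibition and higher numbers for weaker inhibition), compound 2 gives 5000 nM. Compound 1 `O=C(CCc1cccc2c1B(O)OC2)NCc1ccccc1` gives > 100000 nM in this assay, which is a limit of the assay rather than a number. The step of an at least 20-fold lower number from compound 1 to compound 2 (1.30 log units; beyond the scatter) is large, but it concerns a different change. Compound 3 `COc1ccc(NC(=O)CCc2cccc3c2B(O)OC3)cc1` differs from compound 2 by methoxy in place of chloro on an aromatic carbon. Going by the values given here, no measured step covers this change, so the expectation is a result within the scatter or a modest weakening. Compound 3 is expected to give 8000 nM, between 3000 nM and 25000 nM. The expected step is a 1.6-fold higher number from compound 2 to compound 3 (0.20 log units; within the scatter).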

Compound 3, half-maximal inhibitory concentration: 900 nM
Beside the measured number, compound 3's estimate is 8.9-fold (0.95 log units) above it; the measured number lies below the stated range.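

In this assay, methoxy in place of chloro on an aromatic carbon, para to a large group, gives a 5.6-fold lower number from compound 2 to compound 3 (0.74 log units; beyond the scatter). The earlier step changed only the group on the amide-type nitrogen; this one shows that the group on the aromatic ring also shifts the number, and that of these two groups methoxy gives the stronger inhibition. Nothing shown here bears on the reason for this gain.

Still open, going by these compounds, is whether the oxygen or the added carbon matters more. A hydroxy group or a methyl group at the same place would help separate the two.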